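Swapping chloro for fluoro on a sulfonamide aryl ring

The source may hold more compounds than are shown below. What is called first, only, known or untested is meant among the compounds shown, and "the series" means these compounds.

Compound 1 `O=S(=O)(Nc1ccc2oc(-c3ccccc3)nc2c1)c1ccccc1Cl` carries a 2-chlorophenyl sulfonamide on a shared core. In an ADME assay on HEK293 cells (Homo sapiens) for cytotoxicity, read by resazurin assay, with a stated time of 48 h (on this read-out higher numbers stand for lower toxicity in this test and lower numbers for higher toxicity in this test), compound 1 gives 73000 nM, the lowest of the two numbers available. Compound 2 `O=S(=O)(Nc1ccc(-c2nc3ccccc3o2)cc1)c1ccc(C(F)(F)F)cc1` shows 94000 nM in this assay, a value within the usual scatter of that of compound 1, so the two cannot be ordered. Compound 3 `COc1ccccc1S(=O)(=O)Nc1ccc(-c2nc3ccccc3o2)cc1` reaches > 100000 nM in this assay, which is a limit of the measurement rather than a number. That reading is the limit of > 100000 nM in this assay, at which 1 of the 3 values shown sits.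

Compound 4 `O=S(=O)(Nc1ccc2oc(-c3ccccc3)nc2c1)c1ccccc1F` differs from compound 1 in one place: fluoro in place of chloro on an aromatic carbon. Within the data shown here, no measured pair shows the effect of this change, and the numbers available are all near the upper end of the assay. The step of a 1.1-fold higher number from compound 1 to compound 4 (0.04 log units; within the scatter) is therefore expected to be small, with no direction beyond the scatter. Compound 4 is estimated to give 80000 nM in this assay, expected to lie between 35000 nM and 150000 nM, with a fair chance that only a limit is reported.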

Compound 4, half-maximal cytotoxic concentration: 72000 nM
Beside the measured number, compound 4's estimate is 1.1-fold (0.05 log units) above it, within the range that was stated.
By their numbers in this assay, from the lowest: compounds 4, 1 and 2 (each within the scatter of the next). At a limit, above all of these: compound 3.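

Fluoro in place of chloro on the 2-chlorophenyl ring gives a 1.0-fold lower number from compound 1 to compound 4 (0.01 log units; within the scatter) in this assay. This is the only pair shown that differs in one place, and it gives the first direct reading of a single change: on this aromatic carbon, ortho to a large group, exchanging one halogen for the other leaves the read-out unmoved within the scatter. With only this pair, that finding applies to this one swap and not to the ring as a whole, and compound 3 gives a limit rather than a number: the limit of > 100000 nM in this assay, at which 1 of the 4 values shown sits.

The compounds shown leave open whether a different kind of group at this place, such as an amine or a carboxylic acid, would shift the number beyond the scatter. They also leave open what plain hydrogen at this place would give.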